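Octylsulfanyl for trifluoroethoxy on a cytotoxicity-silent core

This account rests on a few compounds, and the source may have more. Where it says the series, first, only, none or still open, it means among the compounds named here.

Three compounds share one core and differ only in the group on a single aromatic carbon. Compound 1 `CCCCSc1nc(N)nc2c1ncn2/C=C1/CC1(CO)CO` carries a butylsulfanyl group there. In an ADME assay on Akata cells (Homo sapiens) for cytotoxicity, with a stated time of 7 days (a higher number here means that more compound is tolerated, a lower number that less compound is tolerated), compound 1 gives > 20000 nM, which is a limit of the assay. Compound 2 `CCCCCOc1nc(N)nc2c1ncn2/C=C1/CC1(CO)CO` carries pentyloxy in its place. In this assay compound 2 gives > 20000 nM, again a limit. Compound 3 `Nc1nc(OCC(F)(F)F)c2ncn(/C=C3/CC3(CO)CO)c2n1` carries 2,2,2-trifluoroethoxy. In this assay compound 3 gives > 20000 nM, also a limit. Because all three sit at the limit of > 20000 nM in this assay, at which 3 of the 3 values shown sit, none of the steps between them can be read: a step that the two limits leave unreadable from compound 1 to compound 2, a step that the two limits leave unreadable from compound 1 to compound 3 and a step that the two limits leave unreadable from compound 2 to compound 3. Compound 3 therefore stands together with the others at the limit, without a number of its own.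

Compound 4 `CCCCCCCCSc1nc(N)nc2c1ncn2/C=C1/CC1(CO)CO` is the one not yet measured; it differs from compound 3 by octylsulfanyl in place of 2,2,2-trifluoroethoxy on an aromatic carbon. The measured steps that touch this position are all unreadable, so they offer neither a size nor a direction for the step to compound 4; the single finding so far is that every compound is tolerated up to the limit. The step from compound 3 to compound 4 is expected to be a number no higher from compound 3 to compound 4 (the limit leaves the size open), that is nothing that can be seen. Compound 4 is estimated at 20000 nM, within 6000 nM to 70000 nM, most probably reported once more as a limit.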

Compound 4, half-maximal cytotoxic concentration: > 20000 nM
Compound 4: no number, only a limit; the forecaster's own chance of this, stated with the estimate: 55%; the middle value sits exactly at the limit.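

In this assay compound 4 gives > 20000 nM as a limit of the assay. The steps to compound 4 from compound 1, compound 2 and compound 3 therefore cannot be read: the limit of > 20000 nM in this assay, at which 4 of the 4 values shown sit. The compounds shown leave open at what concentration any of the four becomes cytotoxic to these cells, and whether the group on this aromatic carbon affects that concentration.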